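Pyridin-3-yl in place of methyl: working notes

This account rests on a few compounds, and the source may have more. Where it says the series, first, only, none or still open, it means among the compounds named here.

- Compound 1 `CCCCOc1cccc(OCc2[nH]c3ccccc3c(=O)c2C)c1`: > 1000 mL/min/kg
- Compound 2 `Cc1ccc2[nH]c(COc3cccc(OCC4CCOCC4)c3)c(C)c(=O)c2c1`: "not determined" (no result reported)
- Compound 3 `O=c1cc(COc2cccc(OCC3CCOCC3)c2)[nH]c2ccccc12`: 197 mL/min/kg

All three compounds were run in an in vitro ADME assay on microsomes from liver (Mus musculus) for metabolic stability, tested at 0.2 uM; a higher number here means faster removal of the compound, a lower number slower removal. Compound 1 gives > 1000 mL/min/kg, which is a limit of the assay and not a number. Compound 2 has no measured clearance, so its place in the series is open. Compound 4 `Cc1c(COc2cccc(OCC3CCOCC3)c2)[nH]c2ccc(-c3cccnc3)cc2c1=O` awaits measurement. The change pyridin-3-yl in place of methyl on an aromatic carbon puts pyridin-3-yl in place of methyl on an aromatic carbon. With no starting number, the step in this assay cannot be read from the data. A moderate step of uncertain direction is expected, with compound 4 landing in the region of compound 3 at 197 mL/min/kg. For compound 4 the clearance is estimated at 300 mL/min/kg, with an expected range of 90 mL/min/kg to 1000 mL/min/kg.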

Compound 4, clearance: > 1000 mL/min/kg
Compound 4: a limit, no number (the forecaster's own chance of this, stated with the estimate: 15%); middle value at least 3.3-fold (0.52 log units) away from the limit.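

Among these compounds, no step from compound 2 to compound 4 can be read: compound 2 has no number, and compound 4 gives only a limit of the assay. The compounds shown leave open how pyridin-3-yl in place of methyl shifts clearance.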